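Methyl for hydrogen on the core of compound 3

A few compounds are considered here, and "the series" means these few. Any claim that something is new, unique, unknown or untested is made for them only; others in the source may bear on it.

Three analogues carry the same core, varied at one aromatic carbon of the fused system and on the benzyl ether. In a functional assay on SMMC-7721 cells (Homo sapiens) for inhibition, read by MTT assay, with a stated time of 72 h, tested at 10 uM (a higher number here means a stronger effect of the compound at the concentration tested, a lower number a weaker effect), compound 1 `Clc1ccc2c(O/N=C(/C=C/c3ccc(OCc4ccccc4Cl)cc3)\C=C\c3ccccn3)ncnc2c1` gives 84.7%. Compound 2 `Cc1cccc(COc2ccc(/C=C/C(/C=C/c3ccccn3)=N/Oc3ncnc4cccc(C)c34)cc2)c1` gives 97% in this assay. Compound 3 `Clc1ccccc1COc1ccc(/C=C/C(/C=C/c2ccccn2)=N/Oc2ncnc3ccccc23)cc1` gives 96.9% in this assay, second highest of the three numbers; its gap to compound 2 lies within the scatter, while the step of a number 12.2 percentage points higher from compound 1 to compound 3 (beyond the scatter) lies beyond it.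

Compound 4 `Cc1cccc2ncnc(O/N=C(/C=C/c3ccc(OCc4ccccc4Cl)cc3)\C=C\c3ccccn3)c12` differs from compound 3 by methyl in place of hydrogen on an aromatic carbon. Among the measured compounds shown here, the only step that touches the same carbon is a number 12.2 percentage points higher from compound 1 to compound 3 (beyond the scatter), a modest gain when chloro is removed. Compound 2, which bears methyl at that carbon alongside a different benzyl group, sits at 97%, within the scatter of compound 3. With compound 3 already near the top of the read-out, the expected step of a number 1.9 percentage points lower from compound 3 to compound 4 (within the scatter) is none beyond the scatter. Compound 4 is therefore estimated at 95% in this assay, in the range 87% to 99%.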

Compound 4, a percentage reported as inhibition, at one concentration (the size of the read-out at that concentration, not a potency): 84.7%
Beside the measured number, compound 4's estimate is 10.3 percentage points above it; measured number outside the range, below it.
By their numbers in this assay, from the lowest: compounds 1 and 4 (each within the scatter of the next); then compounds 3 and 2 (each within the scatter of the next).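

In this assay, methyl on the core of compound 3, giving 5-methylquinazolin-4-yl, produces a number 12.2 percentage points lower from compound 3 to compound 4 (beyond the scatter) as a real loss at this carbon with the 2-chlorophenyl group in place. The loss is not general for this methyl, since compound 2 carries it too, and the exchange of 3-methylphenyl for 2-chlorophenyl gives a number 12.3 percentage points lower from compound 2 to compound 4 (beyond the scatter) as a second drop, so the outcome at this position depends on the benzyl group. With 2-chlorophenyl retained, 5-methylquinazolin-4-yl and 7-chloroquinazolin-4-yl are indistinguishable, with no change at the digits printed from compound 1 to compound 4 (within the scatter) as the step between them.

No measured evidence explains these steps. Open, on these data alone, is whether methoxy, ethyl or an amine at this carbon would follow the methyl, and whether the dependence on the benzyl group extends to other benzyl groups.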